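Lengthening a side chain on a pyridine-ether nicotinic ligand

The compounds below may be only part of what the source reports. "The series", "measured", "known", "first", "only" and "open" are said of these compounds alone.

Compound 1, `CN1CCC[C@H]1COc1cccnc1`, binds tightly in an assay on membranes from brain for displacement of a labelled ligand from Neuronal acetylcholine receptor; alpha4/beta2 (Rattus norvegicus) (a higher number here means a weaker inhibitor, a lower number a stronger inhibitor), giving 0.15 nM. Compound 2, `CCc1cncc(OC[C@@H]2CCCN2C)c1`, carries an ethyl group on one aromatic carbon of the shared core and gives 0.32 nM; the change is a 2.1-fold higher number from compound 1 to compound 2 (0.33 log units; beyond the scatter). On the two numbers available, compound 2 therefore stands as the higher of the pair, separated from compound 1 by a gap that exceeds the usual scatter.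

Compound 3, `CCCCc1cncc(OC[C@@H]2CCCN2C)c1`, takes this one step further: ethyl in place of hydrogen on a saturated chain carbon, two bonds along the chain from an aromatic carbon, so that the ethyl of compound 2 becomes a butyl. For the measured compounds named here, the only measured step that bears on this is the one from compound 1 to compound 2, which added the first two carbons and produced a modest weakening. Adding two more carbons in the same direction is expected, by analogy, to give a further modest weakening in this assay, and no stronger binding. The estimated step is a 2.2-fold higher number from compound 2 to compound 3 (0.34 log units; beyond the scatter). Compound 3 is accordingly expected to give about 0.7 nM, with a plausible range from 0.2 nM to 2.5 nM.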

Compound 3, inhibition constant: 0.16 nM
Beside the measured number, compound 3's estimate is 4.4-fold (0.64 log units) above it; measured number outside the range, below it.
By their numbers in this assay, from the lowest: compounds 1, 3 and 2 (each within the scatter of the next, the first and the last beyond it).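

In this assay, lengthening ethyl to butyl gives a step (a 2.0-fold lower number from compound 2 to compound 3 (0.30 log units; within the scatter)) that cannot be told apart from the usual variation between repeated measurements, so the weakening seen when ethyl replaced hydrogen on the aromatic carbon (a 2.1-fold higher number from compound 1 to compound 2 (0.33 log units; beyond the scatter)) does not continue in the same direction along the chain. Compound 3 also sits level with compound 1, which carries only hydrogen at this place (a 1.1-fold higher number from compound 1 to compound 3 (0.03 log units; within the scatter)), so this position accepts a butyl chain with no loss that this measurement can resolve, and across these three compounds binding does not follow chain length in a simple one-way trend. Nothing available here accounts for this result.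

Still open, from the compounds shown here alone, is whether a longer chain such as hexyl, a branched group such as tert-butyl, or a ring such as phenyl would also stay level with compound 1 at the same place. Equally open, going by these compounds, is how binding would respond to an alcohol or an amine at the far end of the butyl chain, which would show whether this tolerance extends beyond plain carbon chains.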